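Nuclear factor erythroid 2-related factor 2 activators: fluoro for methoxy

The source may report more compounds than this note shows. Statements on the series, on what has been measured and on what is new or still open speak of the compounds shown alone.

compound 1 `COc1ccc(S(=O)(=O)/C=C/c2ccc(Cl)cn2)cc1`: 9360 nM
compound 2 `COc1ccccc1/C=C/S(=O)(=O)c1ccccn1`: 7020 nM

Within the data shown here, in an assay on U2OS cells for activation of nuclear factor erythroid 2-related factor 2 (Homo sapiens), read by chemiluminescence, with a stated time of 6 h (a lower number here means that less compound is needed, a higher number that more compound is needed for the effect), compound 2 gives 7020 nM, the lower of the two numbers so far. Compound 1 gives 9360 nM, and the gap to compound 2 lies within the scatter. Compound 3 `O=S(=O)(/C=C/c1ccccc1F)c1ccccn1` is the next member; it differs from compound 2 by fluoro in place of methoxy on an aromatic carbon. Among the measured compounds shown here, no measured pair shows this change, so no shift beyond the scatter is expected in this assay in either direction. Compound 3 is therefore estimated at 8500 nM, with a range of 3000 nM to 25000 nM. The expected step is a 1.2-fold higher number from compound 2 to compound 3 (0.08 log units; within the scatter).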

Compound 3, half-maximal effective concentration: 1010 nM
Compound 3: middle estimate off by 8.4-fold (0.93 log units), on the high side; measured number below the stated range.
By their numbers in this assay, from the lowest: compound 3; then compounds 2 and 1 (each within the scatter of the next).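

In this assay, among these compounds, the substituent on this aromatic carbon, ortho to a large group, matters: fluoro in place of methoxy gives a 7.0-fold lower number from compound 2 to compound 3 (0.84 log units; beyond the scatter) and is the only single-place change so far. The earlier compounds shown here offered no such pair, so this position had no read-out until now. Nothing available bears on the reason for this step. Open, from the compounds shown here alone, is whether the step belongs to fluoro itself or to the loss of methoxy, which chloro, ethoxy or an amine at the same carbon would help separate. Also open, going by these compounds, is whether the step carries over to other cores.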